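From pyridin-3-yl to furan-2-yl on a shared core

The source may hold more compounds than are shown below. What is called first, only, known or untested is meant among the compounds shown, and "the series" means these compounds.

Values in an ADME assay on HepG2 cells (Homo sapiens) for cytotoxicity, read by MTT assay, with a stated time of 72 h; a lower number here means that less compound is tolerated, a higher number that more compound is tolerated:
compound 1 `O=[N+]([O-])c1c(CS(=O)(=O)c2ccccc2)nc2c(-c3ccc(Cl)cc3)cc(Cl)cn12`: > 3900 nM
compound 2 `O=[N+]([O-])c1c(CS(=O)(=O)c2ccccc2)nc2c(-c3ccc(CO)cc3)cc(Cl)cn12`: 13100 nM
compound 3 `O=[N+]([O-])c1c(CS(=O)(=O)c2ccccc2)nc2c(-c3cccnc3)cc(Cl)cn12`: > 31300 nM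

Compound 3 stands at > 31300 nM, which is a limit and not a number. Compound 1 also gives only a limit, > 3900 nM. Compound 2 alone gives a number, 13100 nM.

Compound 4 `O=[N+]([O-])c1c(CS(=O)(=O)c2ccccc2)nc2c(-c3ccco3)cc(Cl)cn12` carries furan-2-yl in place of the pyridin-3-yl of compound 3 on the same aromatic carbon: furan-2-yl in place of pyridin-3-yl on an aromatic carbon.

Two measured steps change that same carbon and lead to or from pyridin-3-yl. One of them gives no readable size: a step that the two limits leave unreadable from compound 1 to compound 3. The other is an at least 2.3-fold higher number from compound 2 to compound 3 (0.37 log units; beyond the scatter), but it starts from 4-(hydroxymethyl)phenyl and says little about furan-2-yl. No step beyond the scatter is therefore expected in this assay, with a slight lean towards a lower number. The estimated change is an at least 1.2-fold lower number from compound 3 to compound 4 (0.09 log units; that floor lies within the scatter). For compound 4 the expected value is 25000 nM, with an estimated range from 8000 nM to 70000 nM.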

Compound 4, half-maximal cytotoxic concentration: > 3900 nM
Compound 4 was reported as a limit; the forecaster's own chance of this, stated with the estimate: 60%; the middle value lies beyond the limit too.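

In this assay, for the compounds shown here, compound 4 gives > 3900 nM, which is a limit and not a number, so no step to it from compound 1, compound 2 or compound 3 can be read. The compounds shown leave open whether furan-2-yl and pyridin-3-yl differ at all on this carbon in this assay.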